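Series notes: substituents on the double-bonded nitrogen

The source may hold more compounds than are shown below. What is called first, only, known or untested is meant among the compounds shown, and "the series" means these compounds.

Measured so far:
compound 1 `CCCC/N=C(\NC#N)Nc1cccnc1` — 20 mg/kg
compound 2 `CCCCCCC/N=C(\NC#N)Nc1cccnc1` — reported only as a limit, > 50 mg/kg
compound 3 `N#CN/C(=N\C1CCCC1)Nc1cccnc1` — 20 mg/kg

In a functional assay on the whole organism (blood, strain Wistar-Okamoto) with Rattus norvegicus as the target, with a stated time of 5 days (on this read-out lower numbers stand for an effect already at smaller amounts and higher numbers for an effect only at larger amounts of compound), compound 1 gives 20 mg/kg. Compound 3 gives 20 mg/kg, and the step of no change at the digits printed from compound 1 to compound 3 (within the scatter), so the two compounds stand level at the digits shown. For compound 2 the assay gives only a limit, > 50 mg/kg, no number (the limit of > 50 mg/kg in this assay, at which 1 of the 3 values shown sits). The step of an at least 2.5-fold higher number from compound 1 to compound 2 (0.39 log units; beyond the scatter).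

Compound 4 `CCOCC/N=C(\NC#N)Nc1cccnc1` is the next compound, differing from compound 1 by ethoxy in place of ethyl on a saturated chain carbon, two bonds along the chain from a double-bonded nitrogen. Going by the values given here, no measured step covers this change. The step from compound 1 to compound 3 shows that exchanging the group on the double-bonded nitrogen for one of similar size left the read-out unchanged, whereas the step from compound 1 to compound 2 shows that lengthening the chain cost activity; the change to compound 4 keeps the chain at the same length, butyl to 2-ethoxyethyl. For compound 4 the expected step is therefore no change at the digits printed from compound 1 to compound 4 (within the scatter), within the scatter. Compound 4 is estimated at 20 mg/kg, between 8 mg/kg and 50 mg/kg.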

Compound 4, minimum effective dose: > 20 mg/kg
Compound 4 was reported as a limit; the forecaster's own chance of this, stated with the estimate: 25%; the middle value lies on the limit itself.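

In this assay compound 4 stands only as a limit, not as a number: the limit of > 20 mg/kg in this assay, at which 1 of the 4 values shown sits.

Going by these compounds alone, at this position, 2-ethoxyethyl in place of butyl gives a number no lower from compound 1 to compound 4 (the limit leaves the size open), and 2-ethoxyethyl in place of cyclopentyl gives a number no lower from compound 3 to compound 4 (the limit leaves the size open), so ethoxy at unchanged chain length shows no gain over either group, a first reading for a chain carrying an oxygen. The step between compound 2 and compound 4 cannot be read, as both values are limits.

The limit leaves open whether compound 4 sits level with compound 1 or needs a much larger dose. How a 2-methoxyethyl group, a 2-hydroxyethyl group or a 2-aminoethyl group on the double-bonded nitrogen would read remains open on the compounds shown.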